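One Measured Compound and a Fluorinated Neighbour

The source may hold more compounds than are shown below. What is called first, only, known or untested is meant among the compounds shown, and "the series" means these compounds.

Within the data shown here, compound 1 `N#Cc1ccccc1COc1ccc([C@H]2CC[C@@H](C(N)=O)N2)cc1` is the only compound with a number so far: in an ADME assay on a cell-free system (plasma, Rattus norvegicus) for protein binding (on this read-out lower numbers stand for a smaller free fraction and higher numbers for a larger free fraction), compound 1 gives 0.12. Two relatives have no reported result: in this assay compound 2 `NC(=O)[C@@H]1CC[C@H](c2ccc(OCc3ccccc3F)cc2F)N1` stands as "not determined" (no result reported) and compound 3 `COc1cc([C@H]2CC[C@@H](C(N)=O)N2)ccc1OCc1ccccc1F` stands as "not determined" (no result reported), so they offer no comparison. Still unmeasured is compound 4 `NC(=O)[C@@H]1CC[C@H](c2ccc(OCc3cccc(F)c3)cc2)N1`, which has 3-fluorophenyl in place of 2-cyanophenyl on a saturated chain carbon bound to an oxygen on an aromatic ring. Among the measured compounds shown here, no measured pair shows what such a swap does, so no shift beyond the usual scatter is expected. The expected change is a 1.3-fold lower number from compound 1 to compound 4 (0.12 log units; within the scatter), leaning slightly towards a smaller free fraction. In this assay, the estimate for compound 4 is 0.09, with an expected range from 0.05 to 0.17.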

Compound 4, unbound fraction: 0.033
For compound 4 the middle estimate is 2.7-fold (0.44 log units) above the measured one; the whole stated range lies above it.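

The step of a 3.6-fold lower number from compound 1 to compound 4 (0.56 log units; beyond the scatter) shows that the group on a saturated chain carbon bound to an oxygen on an aromatic ring is not a silent part of the molecule in this assay. Changing only 2-cyanophenyl to 3-fluorophenyl leaves a clearly smaller free fraction, which compounds 2 and 3 could not show without numbers. Nothing measured here explains the shift.

On these data alone, because the nitrile leaves and the fluorine enters in one step, their separate contributions remain open. So does the effect of a phenyl ring carrying a carboxylic acid or an amine at this place.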